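The source may hold more compounds than are shown below. What is called first, only, known or untested is meant among the compounds shown, and "the series" means these compounds.

Measured so far:
Compound 1, `CCCCCNc1nc(N)nc2c1cc(-c1ccc(F)cc1)c(=O)n2C`: 79800 nM
Compound 2, `CCCOCCNc1nc(Nc2ccccc2)nc2c1cc(-c1c(Cl)cccc1Cl)c(=O)n2C`: 84700 nM
Compound 3, `CCCCCNc1nc(N)nc2[nH]c(=O)c(-c3c(Cl)cccc3Cl)cc12`: 11000 nM

All three were tested in an ADME assay on Huh-7 cells (Homo sapiens) for cytotoxicity, read by MTT assay, with a stated time of 4 h, at 37 degrees C; a lower number here means that less compound is tolerated, a higher number that more compound is tolerated. Compound 1 gives 79800 nM, the second highest of the three numbers. Compound 2 gives 84700 nM, which lies within the scatter of compound 1, so the two cannot be told apart. Compound 3 gives 11000 nM, a lower number beyond the scatter, so less of compound 3 is tolerated than of compound 1. Compounds 2 and 3 differ from compound 1 in more than one place, so no single change can be read off from them.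

The new compound 4, `CCCOCCNc1nc(N)nc2c1cc(-c1ccc(F)cc1)c(=O)n2C`, differs from compound 1 in one place:

propoxy in place of propyl on a saturated chain carbon, two bonds along the chain from a nitrogen on an aromatic ring

Compound 2 carries the same (2-propoxyethyl)amino chain, and its value in this assay sits near that of compound 1, though compound 2 also differs elsewhere. Nothing in the measured set points to a large shift from this change alone. The step from compound 1 to compound 4 is therefore expected to be small, a 1.0-fold higher number from compound 1 to compound 4 (0.00 log units; within the scatter), in no clear direction and most likely within the scatter. Compound 4 is estimated at 80000 nM, in the range 40000 nM to 160000 nM.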

Compound 4, half-maximal cytotoxic concentration: 54300 nM
Estimate against measurement, compound 4: 1.5-fold (0.17 log units) above; measured number inside the range.
By their numbers in this assay, from the lowest: compound 3; then compounds 4, 1 and 2 (each within the scatter of the next).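

In this assay, replacing propyl with propoxy on a saturated chain carbon, two bonds along the chain from a nitrogen on an aromatic ring, gives a 1.5-fold lower number from compound 1 to compound 4 (0.17 log units; within the scatter). Going by these compounds alone, this is the first comparison in the set that isolates a single change. The earlier compounds shown here each differed from compound 1 in more than one place. It shows that, with the rest of compound 1 held fixed, the pentylamino chain can become a (2-propoxyethyl)amino chain, which carries an oxygen within it, and that compound 1 and compound 4 still cannot be told apart in this measurement; no available evidence offers an explanation for this result.

On these data alone, what remains open is whether this position would tolerate other chains equally well, such as a longer chain or one ending in an amine or a carboxylic acid. It is also unknown whether the same replacement would give a similar result when paired with a different group elsewhere on the shared core.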